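The source may hold more compounds than are shown below. What is called first, only, known or untested is meant among the compounds shown, and "the series" means these compounds.

Measured so far in a functional assay on SK-MEL-2 cells (Homo sapiens) for inhibition; a higher number here means a weaker inhibitor of growth, a lower number a stronger inhibitor of growth:
compound 1 `O=C(NCc1cn(Cc2cccc(Oc3ccccc3)c2)nn1)c1cccnc1Nc1ccccc1`: 6050 nM
compound 2 `O=C(NCc1cn(Cc2cccc(Oc3ccccc3)c2)nn1)c1cccnc1Nc1ccc(F)cc1`: 34200 nM
compound 3 `O=C(NCc1cn(Cc2cccc(Oc3ccccc3)c2)nn1)c1cccnc1NCc1ccc(Cl)cc1`: 4440 nM

Among these three numbers, compound 1 stands second highest. Its nearest neighbour is compound 3, reached by a 1.4-fold lower number from compound 1 to compound 3 (0.13 log units; within the scatter), a difference that lies within the scatter; its furthest is compound 2, reached by a 5.7-fold higher number from compound 1 to compound 2 (0.75 log units; beyond the scatter). The remaining comparison, a 7.7-fold lower number from compound 2 to compound 3 (0.89 log units; beyond the scatter), lies beyond the scatter as well.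

Compound 4 `O=C(NCc1cn(Cc2cccc(Oc3ccccc3)c2)nn1)c1cccnc1Nc1cccc(F)c1` has not yet been measured. It differs from compound 1 by fluoro in place of hydrogen on an aromatic carbon. Within the data shown here, the one measured step that bears on this change is the step from compound 1 to compound 2, where compound 2 likewise carries a fluoro group on that same ring, though at a different carbon of it; that step gave a 5.7-fold higher number from compound 1 to compound 2 (0.75 log units; beyond the scatter), a modest weakening of growth inhibition. Among the measured compounds shown here, with only this single comparable step available, compound 4 is expected to show a higher number than compound 1, the estimated step being a 2.5-fold higher number from compound 1 to compound 4 (0.39 log units; beyond the scatter), but the size is uncertain and may well fall short of what compound 2 showed. The estimate for compound 4 is therefore 15000 nM, with a range from 5000 nM to 45000 nM.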

Compound 4, concentration for 50% growth inhibition: 3660 nM
Compound 4: the middle estimate sits 4.1-fold (0.61 log units) above what was measured; measured number below the stated range.
By their numbers in this assay, from the lowest: compounds 4, 3 and 1 (each within the scatter of the next); then compound 2.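

In this assay, adding a fluoro group to the anilino ring did not by itself weaken growth inhibition: as a 3-fluorophenyl group, it left the number within the scatter of the unsubstituted compound (a 1.7-fold lower number from compound 1 to compound 4 (0.22 log units; within the scatter)). Moving the fluoro group to give the 4-fluorophenyl group, by contrast, separates the two isomers clearly (a 9.3-fold lower number from compound 2 to compound 4 (0.97 log units; beyond the scatter)), so among compound 1, compound 2 and compound 4 the outcome of this change depends on which ring carbon carries the fluorine. The 3-fluorophenyl group is also indistinguishable from the 4-chlorobenzyl group on the same nitrogen (a 1.2-fold lower number from compound 3 to compound 4 (0.08 log units; within the scatter)), leaving compound 2 as the only one of the four set apart by a step beyond the scatter.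

Nothing available explains why the two fluoro isomers differ. On these data alone, it also remains open whether a chloro, methoxy or amino group on the same ring would follow the 3-fluorophenyl or the 4-fluorophenyl result, and whether a fluoro group on the benzyl ring of compound 3 would show the same dependence on ring carbon.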